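The source may report more compounds than this note shows. Statements on the series, on what has been measured and on what is new or still open speak of the compounds shown alone.

Measured so far in a functional assay on COR-L23 cells (Homo sapiens) for antiproliferative activity, read by CellTiter-Glo, with a stated time of 72 h (on this read-out lower numbers stand for stronger inhibition and higher numbers for weaker inhibition), are these compounds

- compound 1 `C[C@H](NC(=O)[C@@H]1CCCN1C)c1ccc(NC(=O)N2CC(c3cccnc3)C2)cc1` gives 38 nM in this test
- compound 2 `C[C@H](NC(=O)c1cccc(F)c1)c1ccc(NC(=O)N2CC(c3cncc(N)c3)C2)cc1` gives 630 nM in this test
- compound 3 `C[C@H](NC(=O)c1ncccn1)c1ccc(NC(=O)N2CC(c3cncc(N)c3)C2)cc1` gives 1380 nM in this test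

Compound 3 has the highest number of the three. Compound 4 `C[C@H](NC(=O)[C@@H]1CCCN1C)c1ccc(NC(=O)N2CC(c3cncc(N)c3)C2)cc1` is not yet measured, and 1-methylpyrrolidin-2-yl in place of pyrimidin-2-yl on a carbonyl carbon is what separates it from compound 3. Within the data shown here, the only measured step at this place is a 2.2-fold higher number from compound 2 to compound 3 (0.34 log units; beyond the scatter) and it was modest. Compound 1 carries the same 1-methylpyrrolidin-2-yl group and reaches 38 nM in this assay but it differs from compound 4 elsewhere, so its number cannot simply be carried over. A clear move toward a lower number is expected, with a 4.6-fold lower number from compound 3 to compound 4 (0.66 log units; beyond the scatter) as the estimated step. For compound 4 the estimate is 300 nM with an expected range from 70 nM to 1300 nM in this measurement.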

Compound 4, half-maximal inhibitory concentration: 200 nM
The estimate for compound 4 lay 1.5-fold (0.18 log units) above the measured number, within the range that was stated.
By their numbers in this assay, from the lowest: compound 1; then compound 4; then compound 2; then compound 3.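

In this assay, 1-methylpyrrolidin-2-yl on this carbonyl carbon gives a lower number than either aromatic group, pyrimidin-2-yl (a 6.9-fold lower number from compound 3 to compound 4 (0.84 log units; beyond the scatter)) or 3-fluorophenyl (a 3.2-fold lower number from compound 2 to compound 4 (0.50 log units; beyond the scatter)). Among these compounds, compounds 1 and 4 also give the first one-place comparison of amino in place of hydrogen on an aromatic carbon, and the number rises (a 5.3-fold higher number from compound 1 to compound 4 (0.72 log units; beyond the scatter)). Nothing shown here gives a reason for either change. Still open, from the compounds shown here alone, is whether an open-chain amine on this carbonyl carbon, or pyrrolidin-2-yl without its methyl group, would give a similar number.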